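This account rests on a few compounds, and the source may have more. Where it says the series, first, only, none or still open, it means among the compounds named here.

Measured compounds:
- compound 1 `Cc1n[nH]c2ccc(-c3nc4cnc(N5CCN(C)CC5)cn4c3Nc3ccccc3F)cc12`: "not determined" (no result reported) in this assay
- compound 2 `Cc1n[nH]c2ccc(-c3nc4cnc(N5CCN(C)CC5)cn4c3Nc3ccc(Br)cc3Cl)cc12`: 9220 nM

Two compounds share the same core and differ only in the aromatic ring attached through the amino group. In a functional assay on MV4-11 cells (Homo sapiens) for inhibition, with a stated time of 120 h (on this read-out lower numbers stand for stronger inhibition and higher numbers for weaker inhibition), compound 1 is recorded as "not determined" (no result reported), so no number exists for it. In this assay, among the measured compounds shown here, compound 2 gives 9220 nM, and this is the only number available, which leaves compound 2 without any comparison among measured compounds.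

Compound 3 `Cc1cc(Br)ccc1Nc1c(-c2ccc3[nH]nc(C)c3c2)nc2cnc(N3CCN(C)CC3)cn12` is not yet measured. It differs from compound 2 by a single swap: methyl in place of chloro on an aromatic carbon. For the measured compounds named here, since no measured pair with a single change exists here, there is no step on which to base the size of this one. The two groups are of the same size in heavy atoms and neither carries a donor or acceptor, so the expectation is a change no larger than the usual scatter, with no clear direction, which is the step of a 1.0-fold lower number from compound 2 to compound 3 (0.01 log units; within the scatter) expected from compound 2 to compound 3. Compound 3 is accordingly estimated at 9000 nM, within a range from 3000 nM to 27000 nM.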

Compound 3, half-maximal inhibitory concentration: 10900 nM
Estimate against measurement, compound 3: 1.2-fold (0.08 log units) below; low and high end bracket the measured number.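

Among the compounds shown here, the swap of chloro for methyl on the aromatic carbon ortho to a large group now gives the first step that can be read in this assay: a 1.2-fold higher number from compound 2 to compound 3 (0.07 log units; within the scatter). This step lies within the scatter, so on this read-out the 4-bromo-2-chlorophenyl and 4-bromo-2-methylphenyl rings cannot be told apart, and in this pair the identity of this one small group makes no measurable difference. Nothing in the data shown gives a reason why these two groups read alike, and a single pair cannot show whether the same would hold on another ring or core.

Both groups compared here have one heavy atom and carry no hydrogen-bond donor or acceptor, so this pair says nothing about how a larger or quite different group would read at this position, such as a primary amine, a carboxylic acid or a longer chain like n-butyl. It also leaves open what the bromo group contributes to the number, since it stays the same in compound 2 and compound 3 and no compound shown replaces it with hydrogen or a methoxy group.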